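The source may hold more compounds than are shown below. What is called first, only, known or untested is meant among the compounds shown, and "the series" means these compounds.

Measured so far in a physicochemical assay for solubility, read by spectrophotometry, in phosphate buffer, with a stated time of 18 h, at pH 7.4; on this read-out lower numbers stand for lower solubility and higher numbers for higher solubility:
compound 1 `CCc1ccc(-c2nc3c(c(C)nn3-c3ccccc3)c(-c3ccccc3F)c2C#N)cc1`: 1700 nM
compound 2 `Cc1nn(-c2ccccc2)c2nc(-c3ccc(C(F)(F)F)cc3)c(C#N)c(-c3ccccc3O)c12`: 3500 nM

Compound 2 stands higher of the two, and the gap to compound 1 lies just beyond the scatter. Among the compounds with values here, no measured pair differs in one place only, so the series offers no direct precedent for the next change.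

Compound 3 `Cc1nn(-c2ccccc2)c2nc(-c3ccc4c(c3)OCCO4)c(C#N)c(-c3ccccc3O)c12` is not yet measured in this assay. It carries 2,3-dihydro-1,4-benzodioxin-6-yl in place of the 4-(trifluoromethyl)phenyl of compound 2, on an aromatic carbon next to the ring nitrogen and ortho to a cyano group: 2,3-dihydro-1,4-benzodioxin-6-yl in place of 4-(trifluoromethyl)phenyl on an aromatic carbon.

The expectation rests on the small spread of the two measured numbers, with compound 1 at 1700 nM and compound 2 at 3500 nM. A small upward move, not beyond the scatter, is the expected outcome, though the data cannot exclude a larger move in either direction. The estimated change is a 1.4-fold higher number from compound 2 to compound 3 (0.15 log units; within the scatter). For compound 3 the expected value is 5000 nM, with an estimated range of 1500 nM to 15000 nM.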

Compound 3, solubility: 11000 nM
For compound 3 the middle estimate is 2.2-fold (0.34 log units) below the measured one; measured number inside the range.
By their numbers in this assay, from the lowest: compound 1; then compound 2; then compound 3.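

In this assay, within the data shown here, the compounds now give a first reading of a single change, at the aromatic carbon next to the ring nitrogen and ortho to a cyano group: 2,3-dihydro-1,4-benzodioxin-6-yl in place of 4-(trifluoromethyl)phenyl gives a 3.1-fold higher number from compound 2 to compound 3 (0.50 log units; beyond the scatter). The read-out at this position therefore responds to the identity of the group, even though the exchange keeps 10 heavy atoms and no net charge on each side, while 0 hydrogen-bond acceptors leave and 2 enter. No measurement here ties the step to any one feature of the two groups.

Among these compounds, the single step cannot separate the oxygen atoms of the entering group from its non-aromatic ring, or from the loss of the trifluoromethyl group, and a methoxy group, an amine or a carboxylic acid on the same aromatic ring would help to tell these apart. On these data alone, the step is also read only with the 2-hydroxyphenyl group in place, so whether it holds with another group there remains open.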